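From 3-methylphenyl to 4-methylphenyl on a sulfonamide nitrogen

The compounds below may be only part of what the source reports. "The series", "measured", "known", "first", "only" and "open" are said of these compounds alone.

In a functional assay on A549 cells (Homo sapiens) for inhibition (on this read-out lower numbers stand for stronger inhibition of growth and higher numbers for weaker inhibition of growth), compound 1 `CC(C)(C)c1ccc(S(=O)(=O)Nc2ccccc2O)cc1` gives 13000 nM. Compound 2 `Cc1ccccc1NS(=O)(=O)c1ccc(C(C)(C)C)cc1` gives > 80000 nM, which is a limit of the assay and not a number. Compound 3 `Cc1cccc(NS(=O)(=O)c2ccc(C(C)(C)C)cc2)c1` gives 80000 nM, the higher of the two actual numbers, and compound 1 is its nearest neighbour among them.

Compound 4 `Cc1ccc(NS(=O)(=O)c2ccc(C(C)(C)C)cc2)cc1`, not yet measured, has 4-methylphenyl in place of 3-methylphenyl on a sulfonamide nitrogen. Two measured steps replace the 2-hydroxyphenyl of compound 1, and both are modest but beyond the scatter: an at least 6.1-fold higher number from compound 1 to compound 2 (0.78 log units; beyond the scatter) and a 6.2-fold higher number from compound 1 to compound 3 (0.79 log units; beyond the scatter). They show higher numbers for the two methyl compounds, but neither is a change of the kind now in question. For the measured compounds named here, the closest precedent is the swap of 2-methylphenyl for 3-methylphenyl, a number no higher from compound 2 to compound 3 (the limit leaves the size open), and its size cannot be read. Going by the values given here, with only that step as a guide, no change beyond the scatter is expected in this assay, and the reading for compound 4 may also come back only as a limit. The expected result is a 1.1-fold lower number from compound 3 to compound 4 (0.06 log units; within the scatter). The estimated value for compound 4 is 70000 nM, with an expected range of 35000 nM to 120000 nM.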

Compound 4, concentration for 50% growth inhibition: 11000 nM
Beside the measured number, compound 4's estimate is 6.4-fold (0.80 log units) above it, outside the stated range (below it).
By their numbers in this assay, from the lowest: compounds 4 and 1 (each within the scatter of the next); then compound 3.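

In this assay, where the methyl sits on the ring carried by the sulfonamide nitrogen turns out to matter, something the earlier methyl compounds could not show: the change to 4-methylphenyl gives a 7.3-fold lower number from compound 3 to compound 4 (0.86 log units; beyond the scatter) and so separates two compounds with the same atoms, joined differently. The result is a 1.2-fold lower number from compound 1 to compound 4 (0.07 log units; within the scatter) for 4-methylphenyl in place of 2-hydroxyphenyl, so the earlier rise in the number on leaving 2-hydroxyphenyl is not a general result of losing the hydroxy group, and among the groups shown, compound 3 and compound 2 go against this level of inhibition of growth while compound 4 does not. Against 2-methylphenyl the result is an at least 7.2-fold lower number from compound 2 to compound 4 (0.86 log units; beyond the scatter) and it points the same way, but its starting reading is a limit of the assay and not a number: the limit of > 80000 nM in this assay, at which 1 of the 4 values shown sits.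

The compounds shown leave open whether this level of inhibition of growth depends on the methyl itself or only on a group at that place on the ring, since an ethyl chain, a methoxy group or an amine there is not among them. They also leave open how a hydroxy group would behave on the ring as 3-hydroxyphenyl or 4-hydroxyphenyl, and they give no reason for the difference between compound 3 and compound 4.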